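Series notes: methyl replaced by methoxy on the aryl ring

The source may report more compounds than this note shows. Statements on the series, on what has been measured and on what is new or still open speak of the compounds shown alone.

Measured in a functional assay for agonist activity at Free fatty acid receptor 1 (Homo sapiens), read by FLIPR, in the presence of a further agent that is not named here; a lower number here means that less compound is needed, a higher number that more compound is needed for the effect:
Compound 1 `O=C1NC(=O)C(Cc2ccc(Oc3ncc(C(F)(F)F)cc3Cl)cc2Cl)S1` gives 26 nM.
Compound 2 `O=C1NC(=O)C(Cc2ccc(Oc3ncc(C(F)(F)F)cc3Cl)cc2)S1` gives 69 nM.
Compound 3 `Cc1cc(Oc2ncc(C(F)(F)F)cc2Cl)ccc1CC1SC(=O)NC1=O` gives 10 nM.

Compound 3 stands lowest of the three, with a 2.6-fold lower number from compound 1 to compound 3 (0.41 log units; beyond the scatter) and a 6.9-fold lower number from compound 2 to compound 3 (0.84 log units; beyond the scatter), both beyond the scatter. Compound 4 `COc1cc(Oc2ncc(C(F)(F)F)cc2Cl)ccc1CC1SC(=O)NC1=O` differs from compound 3 at the aromatic carbon that varies across all three measured compounds: methoxy in place of methyl on an aromatic carbon. Within the data shown here, no measured step swaps methyl for methoxy. What bears on the step is that this carbon responds to its substituent: a 2.7-fold higher number from compound 1 to compound 2 (0.42 log units; beyond the scatter), a 2.6-fold lower number from compound 1 to compound 3 (0.41 log units; beyond the scatter) and a 6.9-fold lower number from compound 2 to compound 3 (0.84 log units; beyond the scatter). Methoxy keeps the carbon substituted, so for compound 4 a change in this assay no larger than these, and tending toward a slightly higher number, is expected, a 1.5-fold higher number from compound 3 to compound 4 (0.18 log units; within the scatter). The estimate for compound 4 is 15 nM, between 5 nM and 45 nM.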

Compound 4, half-maximal effective concentration: 13900 nM
Compound 4: the middle estimate sits 930-fold (2.97 log units) below what was measured; measured number above the stated range.
By their numbers in this assay, from the lowest: compound 3; then compound 1; then compound 2; then compound 4.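

In this assay this carbon, ortho to a (2,4-dioxo-1,3-thiazolidin-5-yl)methyl group, does not accept every substituent: methyl, chloro and hydrogen differ only modestly, but methoxy brings a large loss against methyl (a 1400-fold higher number from compound 3 to compound 4 (3.14 log units; beyond the scatter)). The loss is also large against chloro (a 530-fold higher number from compound 1 to compound 4 (2.73 log units; beyond the scatter)) and against hydrogen (a 200-fold higher number from compound 2 to compound 4 (2.30 log units; beyond the scatter)), so here methoxy is worse than no substituent. Nothing available explains the loss.

The compounds shown do not separate the oxygen of methoxy from the length of the group. Ethyl and hydroxyl on this carbon would bear on that question.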